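Carbamoyl Added to Compound 3: Expected Cell Tolerance

The source may hold more compounds than are shown below. What is called first, only, known or untested is meant among the compounds shown, and "the series" means these compounds.

Measured in an ADME assay on MDCK cells (Canis lupus familiaris) for cytotoxicity, read by microscopy, with a stated time of 72 h; a lower number here means that less compound is tolerated, a higher number that more compound is tolerated:
Compound 1, `COC(=O)C[C@H](N)C(=O)N(Cc1ccc(F)cc1)C1(C(=O)NCc2ccccc2)CCN(Cc2ccccc2)CC1`: 60000 nM
Compound 2, `COC(=O)CCC(=O)N(Cc1ccc(F)cc1)C1(C(=O)NCc2ccccc2)CCN(Cc2ccccc2)CC1`: 16000 nM
Compound 3, `C[C@H](NC(=O)OC(C)(C)C)C(=O)N(Cc1ccc(F)cc1)C1(C(=O)NCc2ccccc2)CCN(Cc2ccccc2)CC1`: > 100000 nM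

Compound 3 stands at the limit of this assay, (the limit of > 100000 nM in this assay, at which 1 of the 3 values shown sits), so only a floor is known for it and not a number. Compound 4, `CC(C)(C)OC(=O)N[C@@H](CC(N)=O)C(=O)N(Cc1ccc(F)cc1)C1(C(=O)NCc2ccccc2)CCN(Cc2ccccc2)CC1`, differs from compound 3 by carbamoyl in place of hydrogen on a saturated chain carbon, two bonds along the chain from an amide-type nitrogen and a carbonyl carbon. The nearest measured step is a 3.8-fold lower number from compound 1 to compound 2 (0.57 log units; beyond the scatter), where losing an amino group lowered the number; read the other way, adding a group with a hydrogen-bond donor raised it. The step of an at least 6.2-fold higher number from compound 2 to compound 3 (0.79 log units; beyond the scatter) also rose to the limit. Compound 4 is therefore expected to stay at or beyond the limit, a step that the limit leaves unreadable from compound 3 to compound 4. Compound 4 is estimated at 120000 nM, from 50000 nM to 300000 nM.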

Compound 4, minimum cytotoxic concentration: > 100000 nM
Compound 4: a limit, no number (the forecaster's own chance of this, stated with the estimate: 70%); the middle value is on the limit's open side.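

No step can be read from compound 3 to compound 4, since both sit at a limit of this assay and not at a number: the limit of > 100000 nM in this assay, at which 2 of the 4 values shown sit. Going by these compounds, whether carbamoyl in place of hydrogen changes cell tolerance at all, and in which direction, stays open.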